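Swapping fluoro for nitro on the cinnamide arm

This account rests on a few compounds, and the source may have more. Where it says the series, first, only, none or still open, it means among the compounds named here.

Compounds measured in a functional assay on HT-29 cells (Homo sapiens) for cytotoxicity, read by MTT assay, with a stated time of 72 h; on this read-out higher numbers stand for weaker inhibition and lower numbers for stronger inhibition:
Compound 1 `COc1ccc(C(=O)c2cc(OC)c(OC)c(OC)c2)cc1N` gives 50 nM.
Compound 2 `COc1cccc(/C=C/C(=O)Nc2cc(OC)c(OC)c(OC)c2)c1` gives 2400 nM.
Compound 3 `COc1ccc(C(=O)c2cc(OC)c(OC)c(OC)c2)cc1NC(=O)/C=C/c1ccc(F)cc1` gives 1800 nM.

On these numbers compound 3 stands second highest of three: its number lies within the scatter of compound 2, and far above compound 1, as the step of a 36-fold higher number from compound 1 to compound 3 (1.56 log units; beyond the scatter) shows. Compound 4 `COc1ccc(C(=O)c2cc(OC)c(OC)c(OC)c2)cc1NC(=O)/C=C/c1ccc([N+](=O)[O-])cc1` differs from compound 3 by nitro in place of fluoro on an aromatic carbon. Within the data shown here, no measured step concerns such an exchange on this ring; the one step known, a 36-fold higher number from compound 1 to compound 3 (1.56 log units; beyond the scatter), concerns adding the whole cinnamide arm and says nothing about what sits on its far end. Among the measured compounds shown here, with no bearing step, no change beyond the scatter is expected in this assay, so the expected step is no change at the digits printed from compound 3 to compound 4 (within the scatter). Compound 4 is therefore estimated at 1800 nM, between 600 nM and 5400 nM.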

Compound 4, half-maximal inhibitory concentration: 5100 nM
For compound 4 the middle estimate is 2.8-fold (0.45 log units) below the measured one; low and high end bracket the measured number.
By their numbers in this assay, from the lowest: compound 1; then compounds 3 and 2 (each within the scatter of the next); then compound 4.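

The group at the far end of the cinnamide arm does matter: in this assay, nitro in place of fluoro gives a 2.8-fold higher number from compound 3 to compound 4 (0.45 log units; beyond the scatter) and so weaker inhibition. Among these compounds, this is the first sign that this aromatic carbon responds to an exchange of its group, and not only to adding the whole arm. Nothing measured here explains the shift.

As far as these compounds go, what an amine or a carboxylic acid would give on this aromatic carbon stays open. So does whether any group here could lower the number rather than raise it.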